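The compounds below may be only part of what the source reports. "The series", "measured", "known", "first", "only" and "open" are said of these compounds alone.

Measured so far:
compound 1 `O=C(COc1ccc(C(=O)/C=C/c2ccccc2Cl)cc1)N[C@H]1CCOC1=O` — 4610 nM
compound 2 `C=CCc1ccc(OCCSC(=S)N[C@H]2CCOC2=O)c(OC)c1` — > 64000 nM (a limit of the assay)

In a functional assay on PC-3 cells (Homo sapiens) for antiproliferative activity, read by MTT assay, with a stated time of 72 h (on this read-out lower numbers stand for stronger inhibition and higher numbers for weaker inhibition), compound 1 gives 4610 nM, the only number shown in the series. Compound 2 gives a limit of the assay, > 64000 nM; the series thus holds (the limit of > 64000 nM in this assay, at which 1 of the 2 values shown sits). Among the measured compounds shown here, no step between measured compounds is available to calibrate the change.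

Compound 3 `O=C(COc1ccc(C(=O)/C=C/c2ccccc2Br)cc1)N[C@H]1CCOC1=O` differs from compound 1 by bromo in place of chloro on an aromatic carbon. For the step from compound 1 to compound 3 the expectation in this assay is a change that stays within the usual scatter, in either direction: a 1.2-fold lower number from compound 1 to compound 3 (0.06 log units; within the scatter). Compound 3 is therefore estimated at 4000 nM, with a range of 1500 nM to 12000 nM.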

Compound 3, half-maximal inhibitory concentration: 3260 nM
The estimate for compound 3 lay 1.2-fold (0.09 log units) above the measured number; the measured number falls inside the stated range.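

In this assay the series now has its first calibrated step, a 1.4-fold lower number from compound 1 to compound 3 (0.15 log units; within the scatter), for bromo in place of chloro on an aromatic carbon, ortho to a large group. At this place on the shared core, the exchange of one halogen for the other gives no readable change. Among the compounds shown here, nothing measured so far bears on the reason for this result.

Only these two halogens are compared at this place. Going by these compounds, how an amine or a carboxylic acid would read there remains open.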